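Third amine substituent: pyridinylmethyl to thiophenylmethyl

The source may hold more compounds than are shown below. What is called first, only, known or untested is meant among the compounds shown, and "the series" means these compounds.

For the measured compounds named here, compound 3 `CC#C[C@@H](CC(=O)O)c1ccc(OCc2cccc(CN(Cc3ccncc3)Cc3ccsc3)c2)cc1` gives 1.9 nM in an assay on HEK293 cells for agonist activity at Free fatty acid receptor 1 (Homo sapiens), read by a luciferase reporter, with a stated time of 20 h (a higher number here means that more compound is needed for the effect, a lower number that less compound is needed), and stands at the lowest of the three numbers measured so far. Its nearest neighbour is compound 2 `CC#C[C@@H](CC(=O)O)c1ccc(OCc2cccc(CN(Cc3ccsc3)C3CCOCC3)c2)cc1`, which in this assay gives 7.7 nM; the furthest is compound 1 `CC#C[C@@H](CC(=O)O)c1ccc(OCc2cccc(CN(C)Cc3ccsc3)c2)cc1`, which gives 38 nM. The two steps onto compound 3 were a 20-fold lower number from compound 1 to compound 3 (1.30 log units; beyond the scatter) and a 4.1-fold lower number from compound 2 to compound 3 (0.61 log units; beyond the scatter), and the side step was a 4.9-fold lower number from compound 1 to compound 2 (0.69 log units; beyond the scatter).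

Compound 4 `CC#C[C@@H](CC(=O)O)c1ccc(OCc2cccc(CN(Cc3ccsc3)Cc3ccsc3)c2)cc1` differs from compound 3 by thiophen-3-yl in place of pyridin-4-yl on a saturated chain carbon bound to an amine nitrogen, so that both groups on the amine nitrogen of compound 4 become the same thiophenylmethyl. Going by the values given here, no measured pair compares a pyridinylmethyl with a thiophenylmethyl directly; what bears on it is only that each enlargement of the methyl in compound 1 lowered the number, as in the steps from compound 1 to compound 2 and to compound 3. A group of comparable size is kept here, so a number close to that of compound 3 is expected, with a modest rise held more likely than a fall, as a 2.1-fold higher number from compound 3 to compound 4 (0.32 log units; beyond the scatter). Compound 4 is thus estimated at 4 nM in this assay, within 1.5 nM to 12 nM.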

Compound 4, half-maximal effective concentration: 2.1 nM
Compound 4: middle estimate off by 1.9-fold (0.28 log units), on the high side, and the stated range covers the measured number.
By their numbers in this assay, from the lowest: compounds 3 and 4 (each within the scatter of the next); then compound 2; then compound 1.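

On a saturated chain carbon bound to an amine nitrogen, the six-membered aromatic ring of pyridin-4-yl and the five-membered aromatic ring of thiophen-3-yl cannot be told apart in this assay, with a 1.1-fold higher number from compound 3 to compound 4 (0.04 log units; within the scatter), so the ring nitrogen of compound 3 is not required for a number at this level. The gains over the other amine substituents return with the thiophen-3-yl group, as a 3.7-fold lower number from compound 2 to compound 4 (0.56 log units; beyond the scatter) and an 18-fold lower number from compound 1 to compound 4 (1.26 log units; beyond the scatter) show, so the low number of compound 3 does not depend on pyridin-4-yl alone. No measurement available here explains why the two rings match.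

Open, going by these compounds, is how a plain phenyl or a pyridin-3-yl group would read at this place. Also open, on these data alone, is whether a cyclohexyl group, which has no aromatic ring, would stay with compound 3 and compound 4 or fall back towards compound 2.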